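This account rests on a few compounds, and the source may have more. Where it says the series, first, only, none or still open, it means among the compounds named here.

Measured compounds:
Compound 1, `CCCCCC1C(C(=O)OCCCc2cccnc2)=C(C)N=C(C)/C1=C(/O)OCCCN1CCN(Cc2ccccc2)CC1`, gives 33000 nM in a functional assay (aorta) for antagonist activity, with Rattus norvegicus as the target; on this read-out lower numbers stand for stronger inhibition and higher numbers for weaker inhibition.
Compound 2, `CCCCCC1C(C(=O)OCCc2ccc(N(C)C)cc2)=C(C)N=C(C)/C1=C(/O)OCCCc1cccnc1`, gives 45000 nM in this assay.

Among the compounds with values here, compound 1 and compound 2 are the only two measured members of this set, and the gap between their two numbers is within the scatter of this assay, so neither can be placed ahead of the other; both sit at weak inhibition.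

Compound 3, `CCCCCC1C(C(=O)OCCCc2cccnc2)=C(C)N=C(C)/C1=C(/O)OCCCN1CCN(C(c2ccccc2)c2ccccc2)CC1`, is not yet measured. It differs from compound 1 by phenyl in place of hydrogen on a saturated chain carbon bound to an amine nitrogen in a ring and an aromatic carbon. Within the data shown here, no step between measured compounds touches this position, so there is no precedent in the set for what the added phenyl does in this assay. Given that compound 1 and compound 2 share one range of weak inhibition, compound 3 is expected to stay near that range, with a step of a 1.3-fold lower number from compound 1 to compound 3 (0.12 log units; within the scatter) that may fall inside the scatter or reach a modest size in either direction. The estimate for compound 3 is 25000 nM, between 6000 nM and 90000 nM.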

Compound 3, half-maximal inhibitory concentration: 175000 nM
Estimate against measurement, compound 3: 7.0-fold (0.85 log units) below; measured number above the stated range.
By their numbers in this assay, from the lowest: compounds 1 and 2 (each within the scatter of the next); then compound 3.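

In this assay, within the data shown here, phenyl in place of hydrogen on a saturated chain carbon bound to an amine nitrogen in a ring and an aromatic carbon gives a 5.3-fold higher number from compound 1 to compound 3 (0.72 log units; beyond the scatter), the first step in this set to touch this position. It shows that the position is not indifferent to substitution: the added phenyl moves the compound toward weaker inhibition, by a modest step that lies beyond the scatter. Nothing measured here points to a cause for this step.

Going by these compounds, whether methyl or hydroxyl in place of that hydrogen would move the number the same way stays open, since this single step cannot separate the effect of phenyl from that of any substituent there. Also open, on these data alone, is whether a pyridyl ring at this carbon would give a step of similar size and direction.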